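The source may report more compounds than this note shows. Statements on the series, on what has been measured and on what is new or still open speak of the compounds shown alone.

Measured so far in a functional assay on NCI-H460 cells (Homo sapiens) for inhibition, read by MTT assay, with a stated time of 72 h; on this read-out higher numbers stand for weaker inhibition and lower numbers for stronger inhibition:
Compound 1, `CSc1cc[nH]c(=O)n1`: > 100000 nM, a limit of this assay rather than a number.
Compound 2, `O=C(CCl)Nc1cn(COC(CO)CO)c(=O)[nH]c1=O`: 24000 nM.

Compound 1 stands at the limit of > 100000 nM in this assay, at which 1 of the 2 values shown sits; of the two values shown it is the one that gives only a limit, so its inhibition cannot be placed more closely than that. Going by the values given here, compound 2 is the only compound with a number, and that number speaks for weak inhibition. Among the compounds with values here, no two measured compounds differ in a single place, so there is no measured step to set a scale for the change that follows.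

Compound 3, `O=c1nc(NO)cc[nH]1`, has not yet been measured. It differs from compound 1 in one way: hydroxyamino in place of methylsulfanyl on an aromatic carbon. Hydroxyamino now stands on the aromatic carbon where methylsulfanyl stood, and the rest of the shared core is unchanged. Compound 1 gives only a limit. Compound 3 is accordingly expected to stay at that limit as well, with the expected step being a number no higher from compound 1 to compound 3 (the limit leaves the size open), no change beyond the scatter. Compound 3 is estimated at 100000 nM, in a range from 30000 nM to 300000 nM.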

Compound 3, half-maximal inhibitory concentration: > 100000 nM
Compound 3: only a limit was reported; the forecaster's own chance of this, stated with the estimate: 80%; the middle value sits exactly at the limit.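

In this assay compound 1 and compound 3 each give only a limit, so no step can be read between them: the limit of > 100000 nM in this assay, at which 2 of the 3 values shown sit. The compounds shown leave open how strongly either one inhibits, and whether hydroxyamino in place of methylsulfanyl on an aromatic carbon changes inhibition at all.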